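Methyl on the nitrooxymethyl arm of compound 2

A few compounds are considered here, and "the series" means these few. Any claim that something is new, unique, unknown or untested is made for them only; others in the source may bear on it.

Compound 2 `COc1ccc(C2=NN(C(=O)CO[N+](=O)[O-])C(c3ccco3)C2)cc1OC` gives 32% in a functional assay on the whole organism (strain albino) for inhibition, with Rattus norvegicus as the target, read by paw edema, with stated times of 30 min and 1 h, at a dose of 100 mg/kg by the oral route (a lower number here means less inhibition, a higher number more inhibition at the dose given (going by the name of the read-out)), the lowest of the three numbers shown. Compound 3 `COc1ccc(C2=NN(C(=O)CO[N+](=O)[O-])C(c3c(Cl)cccc3Cl)C2)cc1OC` gives 40%, and the step of a number 8 percentage points higher from compound 2 to compound 3 (within the scatter) lies within the scatter. Compound 1 `COc1ccc(C2=NNC(c3ccco3)C2)cc1OC` gives 45%, and the step of a number 13 percentage points lower from compound 1 to compound 2 (beyond the scatter) is the only one beyond the scatter. Compound 4 `COc1ccc(C2=NN(C(=O)C(C)O[N+](=O)[O-])C(c3ccco3)C2)cc1OC` differs from compound 2 by methyl in place of hydrogen on a saturated chain carbon bound to a carbonyl carbon and an oxygen on an unsaturated carbon. Neither measured step touches this saturated chain carbon: one changes the nitrogen substituent as a whole, the other the group on the saturated ring carbon. Among the compounds with values here, no measured step therefore bears directly on this change, and compound 4 is expected to show a step of no change at the digits printed from compound 2 to compound 4 (within the scatter) that stays within the scatter. Compound 4 is estimated at 32%, in the range 20% to 45%.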

Compound 4, a percentage reported as inhibition, in the whole organism at one dose (the size of the read-out at that dose, not a potency): 35%
Beside the measured number, compound 4's estimate is 3 percentage points below it; the range from low to high includes it.
By their numbers in this assay, from the lowest: compounds 2, 4, 3 and 1 (each within the scatter of the next, the first and the last beyond it).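

In this assay, methyl in place of hydrogen on this saturated chain carbon gives a number 3 percentage points higher from compound 2 to compound 4 (within the scatter), so the read-out separates the 1-(nitrooxy)ethyl arm from the (nitrooxy)methyl arm by no more than the scatter. The step of a number 10 percentage points lower from compound 1 to compound 4 (within the scatter) also stays within the scatter, unlike a number 13 percentage points lower from compound 1 to compound 2 (beyond the scatter), but this contrast rests on a small difference and does not set the two arms apart. No evidence bears on a cause for these steps. The compounds shown leave open whether an ethyl or a phenyl on this chain carbon would give a similar number. They also leave open whether methyl would do so alongside 2,6-dichlorophenyl on the saturated ring carbon.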